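Trifluoromethyl Added to an Inactive Aniline Analogue

The source may report more compounds than this note shows. Statements on the series, on what has been measured and on what is new or still open speak of the compounds shown alone.

Compound 3 `C=C(Br)C(=O)Nc1cccc(/C=C2\SC(=O)N(Cc3ccccc3)C2=O)c1`, compound 1 `C=C(Br)C(=O)Nc1cccc(/C=C2\SC(=O)N(Cc3ccc(C(F)(F)F)cc3)C2=O)c1`, compound 2 `Nc1cccc(/C=C2\SC(=O)N(Cc3ccccc3)C2=O)c1` and compound 4 `Nc1cccc(/C=C2\SC(=O)N(Cc3ccc(C(F)(F)F)cc3)C2=O)c1` share one core. In a functional assay on CCRF-CEM cells (Homo sapiens) for cytotoxicity, read by cell counting, with a stated time of 3 days (a lower number here means a stronger inhibitor, a higher number a weaker inhibitor), compound 3 gives 510 nM and compound 1 gives 920 nM; the step of a 1.8-fold higher number from compound 3 to compound 1 (0.26 log units; within the scatter) comes from trifluoromethyl in place of hydrogen on an aromatic carbon. For compound 2 the assay reports only a limit, not a number: in this assay compound 2 gives > 250000 nM. Compound 2 differs from compound 3 by hydrogen in place of (1-bromoethenyl)carbonyl on a nitrogen on an aromatic ring, and the step is an at least 490-fold lower number from compound 2 to compound 3 (2.69 log units; beyond the scatter). Compound 4 is compound 2 carrying the same change as from compound 3 to compound 1, namely (trifluoromethyl in place of hydrogen on an aromatic carbon), at the same place. Because compound 2 already sits at the limit of > 250000 nM in this assay, at which 1 of the 3 values shown sits, and the earlier step stayed within the scatter, the expected step is a step that the limit leaves unreadable from compound 2 to compound 4. Compound 4 is therefore estimated at 300000 nM, most likely again reported only as a limit.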

Compound 4, half-maximal inhibitory concentration: > 250000 nM
Compound 4 ended at the assay's limit (the forecaster's own chance of this, stated with the estimate: 90%); the middle value does not contradict the limit.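

In this assay compound 4 gives > 250000 nM, a limit of the assay and not a number. The trifluoromethyl step between compound 2 and compound 4 cannot be read, as both ends are limits, so the compounds do not show whether this change does the same on the core without (1-bromoethenyl)carbonyl as on the core that carries it. Hydrogen in place of (1-bromoethenyl)carbonyl on the nitrogen does give a readable result, an at least 270-fold higher number from compound 1 to compound 4 (2.43 log units; beyond the scatter), and this large effect appears on both cores: the same change on two cores in this assay, an at least 490-fold lower number (2.69 log units; beyond the scatter) from compound 2 to compound 3 and an at least 270-fold lower number (2.43 log units; beyond the scatter) from compound 4 to compound 1; the limit leaves it open whether they differ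

The compounds shown leave open how a smaller acyl group such as acetyl would behave on that nitrogen. They also leave open whether chlorine or a nitrile in place of trifluoromethyl would change the result.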